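This account rests on a few compounds, and the source may have more. Where it says the series, first, only, none or still open, it means among the compounds named here.

Compound 2 `Cc1ccc(-c2nn(CCCN3CCN(c4cccc(Cl)c4)CC3)c(=S)[nH]2)cc1` is one of two compounds tested in a functional assay on U-937 cells (Homo sapiens) for cytotoxicity, read by MTT assay, with a stated time of 24 h; a higher number here means a weaker inhibitor, a lower number a stronger inhibitor. In this assay compound 2 gives only a limit, > 300000 nM, and not a number. Compound 1 `CC(C)(C)c1ccc(-c2nn(CCCN3CCN(c4cccc(Cl)c4)CC3)c(=S)[nH]2)cc1` behaves alike: in this assay compound 1 gives > 300000 nM, again a limit. For the measured compounds named here, the single measured step, a step that the two limits leave unreadable from compound 1 to compound 2, stays unreadable because of the limit of > 300000 nM in this assay, at which 2 of the 2 values shown sit. Compound 3 `S=c1[nH]c(-c2ccc(Cl)cc2)nn1CCCN1CCN(c2cccc(Cl)c2)CC1` differs from compound 2 by chloro in place of methyl on an aromatic carbon. Going by the values given here, no measured step bears on this change, so no shift beyond the scatter is expected in this assay, in either direction. Compound 3 is expected to give about 400000 nM, within 150000 nM to 1000000 nM, the expected step being a step that the limit leaves unreadable from compound 2 to compound 3.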

Compound 3, half-maximal inhibitory concentration: 28200 nM
Estimate against measurement, compound 3: 14-fold (1.15 log units) above; measured number outside the range, below it.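

Chloro in place of methyl at the aromatic carbon para to a large group gives an at least 10-fold lower number from compound 2 to compound 3 (1.02 log units; beyond the scatter) in this assay, so this position can move the result, which the earlier pair could not show. The swap exchanges one heavy atom for one heavy atom, yet the number still falls beyond the scatter. Chloro in place of tert-butyl gives an at least 10-fold lower number from compound 1 to compound 3 (1.02 log units; beyond the scatter).

As far as these compounds go, how a fluoro, a methoxy or an amine would read at this carbon stays open. From the compounds shown here alone, the full size of both steps also stays open: compound 1 and compound 2 give limits, not numbers.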